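Glycal acetate sulfonamides: ethyl against 4-methylphenyl on sulfur

The source may report more compounds than this note shows. Statements on the series, on what has been measured and on what is new or still open speak of the compounds shown alone.

compound 1 `CC(=O)OC[C@H]1O[C@H](NS(=O)(=O)c2ccc(C)cc2)C=C[C@@H]1OC(C)=O` — 829000000 nM
compound 2 `CCS(=O)(=O)N[C@@H]1C=C[C@@H](OC(C)=O)[C@@H](COC(C)=O)O1` — > 1000000000 nM

In a functional assay on A549 cells (Homo sapiens) for cytotoxicity, read by MTT assay, with a stated time of 24 h (a lower number here means a stronger inhibitor, a higher number a weaker inhibitor), compound 1 gives 829000000 nM. For compound 2 this assay reports only a limit, > 1000000000 nM; compound 2 thus sits at the limit of > 1000000000 nM in this assay, at which 1 of the 2 values shown sits, and no number is known for it. Compound 3 `CC(=O)OC[C@H]1O[C@H](NS(=O)(=O)c2ccc(C)cc2)C=C[C@H]1OC(C)=O` is not yet measured. It differs from compound 2 by 4-methylphenyl in place of ethyl on a sulfonyl sulfur. For the measured compounds named here, no step between measured compounds is available. Compound 1 also carries 4-methylphenyl on the sulfonyl sulfur and gives a measurable 829000000 nM, which supports an expectation of stronger inhibition. The step of an at least 1.2-fold lower number from compound 2 to compound 3 (0.09 log units; that floor lies within the scatter) is expected toward stronger inhibition. Compound 3 is expected near 800000000 nM, between 300000000 nM and 1000000000 nM.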

Compound 3, half-maximal inhibitory concentration: > 1000000000 nM
Compound 3 ended at the assay's limit; the forecaster's own chance of this, stated with the estimate: 40%; at least 1.2-fold (0.09 log units) between middle value and limit.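

In this assay, 4-methylphenyl on the sulfonyl sulfur does not by itself secure a measurable number, and the step between compound 2 and compound 3 cannot be read, since both values are limits. For the compounds shown here, the only readable step is an at least 1.2-fold higher number from compound 1 to compound 3 (0.08 log units; that floor lies within the scatter), and the configuration as drawn is the sole difference behind it: the fact that compounds 1 and 3 differ only in the configuration as drawn.

Going by these compounds, whether compound 1 and compound 3 truly differ stays open, since that floor does not clear the scatter. Also open, on these data alone, is how a longer chain or an amine-bearing chain in place of ethyl on the sulfonyl sulfur would read in this assay.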